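The source may report more compounds than this note shows. Statements on the series, on what has been measured and on what is new or still open speak of the compounds shown alone.

Measured so far:
- compound 1 `O=C1C=C(N2CCN(c3ccccc3)CC2)C(=O)c2c(O)ccc(O)c21`: 1500 nM
- compound 2 `O=C1C=C(N2CCC(c3ccccc3)CC2)C(=O)c2c(O)cccc21`: 700 nM

In a functional assay on OS-RC-2 cells (Homo sapiens) for antiproliferative activity, read by MTT assay, with a stated time of 72 h (on this read-out lower numbers stand for stronger inhibition and higher numbers for weaker inhibition), compound 2 gives 700 nM, the lowest of the two numbers. Its nearest neighbour, compound 1, gives 1500 nM, and the gap between them lies beyond the usual scatter. These two compounds differ in more than one place, so their values show only that gap and do not isolate the effect of any single structural feature.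

The next compound is compound 3 `Cc1ccccc1C1CCN(C2=CC(=O)c3cccc(O)c3C2=O)CC1`. It differs from compound 2 by methyl in place of hydrogen on an aromatic carbon, ortho to a large group, which turns phenyl into 2-methylphenyl.

Among the measured compounds shown here, no measured pair shows a change of this kind, so the data offer no direct precedent, and compound 2 at 700 nM is the only anchor. A small step toward weaker inhibition in this assay is expected, with no change beyond the scatter as the likeliest outcome. The estimated step is a 1.1-fold higher number from compound 2 to compound 3 (0.06 log units; within the scatter). The expected value for compound 3 is 800 nM, with an estimated range of 300 nM to 2000 nM.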

Compound 3, half-maximal inhibitory concentration: 3200 nM
For compound 3 the middle estimate is 4.0-fold (0.60 log units) below the measured one, outside the stated range (above it).
By their numbers in this assay, from the lowest: compound 2; then compound 1; then compound 3.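

In this assay, among the compounds shown here, the change of phenyl to 2-methylphenyl gives a 4.6-fold higher number from compound 2 to compound 3 (0.66 log units; beyond the scatter) and is the first step that isolates a single change. It shows that this aromatic carbon, ortho to a large group, is not indifferent to substitution: adding one carbon, with no ring, no hydrogen-bond donor or acceptor and no net charge, moves the read-out toward weaker inhibition, beyond the usual scatter. No measurement at hand accounts for this shift, so it stands as an observation without an assigned cause.

Going by these compounds, with a single substituent at a single position, the step cannot show whether the loss belongs to methyl in particular or to any replacement of hydrogen on this carbon, so it remains open whether fluorine, methoxy or an amine at the same place would give a step of similar direction and size. On these data alone, it also remains open whether the same change to 2-methylphenyl, carried over to the phenyl of compound 1, would move the number the same way on that different core.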